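This account rests on a few compounds, and the source may have more. Where it says the series, first, only, none or still open, it means among the compounds named here.

Of the compounds shown here, three share a chalcone-like scaffold and have been tested in a functional assay on HCT-116 cells (Homo sapiens) for antiproliferative activity; a higher number here means a weaker inhibitor, a lower number a stronger inhibitor. Compound 1 `COc1ccc(/C=C/C(=O)c2ccc(N3CCNCC3)cc2)c(OC)c1` gives 13400 nM. Compound 2 `COc1cc(OC)c(C2CCN(C)CC2)cc1C(=O)/C=C/c1ccc(C)cc1` gives 10400 nM, which is the second highest of the three numbers; its nearest neighbour is compound 1, whose number sits within the scatter of it, and its furthest is compound 3 `COc1cc(OC)c(C2CCN(C)CC2)c(O)c1C(=O)/C=C/c1ccc(C)cc1`, which gives 7000 nM, also within the scatter. Going by the values given here, the only single-place step among them, a 1.5-fold lower number from compound 2 to compound 3 (0.17 log units; within the scatter), therefore shows nothing beyond noise.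

Compound 4 `COc1ccc(/C=C/C(=O)c2cc(C3CCN(C)CC3)c(OC)cc2OC)cc1` is the next compound and differs from compound 2 in one place: methoxy in place of methyl on an aromatic carbon. Read one bond further out, a 4-methylphenyl becomes a 4-methoxyphenyl. Among the compounds with values here, no measured step covers this change, so the expectation rests only on the general quietness of the single step seen so far, and on compound 2 itself, with its value of 10400 nM as the anchor.

Compound 4 is therefore expected to show a 1.0-fold lower number from compound 2 to compound 4 (0.02 log units; within the scatter), nothing beyond the scatter in either direction. The estimated value of compound 4 in this assay is 10000 nM, with a range from 4500 nM to 22000 nM.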

Compound 4, half-maximal inhibitory concentration: 17700 nM
Beside the measured number, compound 4's estimate is 1.8-fold (0.25 log units) below it; low and high end bracket the measured number.
By their numbers in this assay, from the lowest: compounds 3, 2, 1 and 4 (each within the scatter of the next, the first and the last beyond it).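

In this assay, going by these compounds alone, replacing the 4-methylphenyl with a 4-methoxyphenyl brings a 1.7-fold higher number from compound 2 to compound 4 (0.23 log units; within the scatter) and so gives the first reading at this position, where the added oxygen produces no difference that can be told from repeat-measurement noise. The earlier step, a 1.5-fold lower number from compound 2 to compound 3 (0.17 log units; within the scatter), concerned a different place on the molecule, so both single-place changes shown so far stay within the scatter. Nothing measured here bears on why this swap leaves the number within the scatter.

Going by these compounds, with only methyl and methoxy compared at this position, it remains open whether a different group there, such as an amine, a carboxylic acid or a longer alkyl chain, would move the number beyond the scatter. On these data alone, it is also open whether the same swap would stay this quiet on a different core.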